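Replacing 1H-benzimidazol-2-yl with 4-methylphenyl in compound 1

The source may hold more compounds than are shown below. What is called first, only, known or untested is meant among the compounds shown, and "the series" means these compounds.

Compound 1 `Cc1cc(N2CC[C@@H](C)[C@@H](N(C)c3ncnc4[nH]ccc34)C2)n2nc(SCc3nc4ccccc4[nH]3)nc2n1`: > 100000 nM, a limit
Compound 2 `C[C@@H]1CCN(c2cc(-c3ccccc3)nc3ncnn23)C[C@@H]1N(C)c1ncnc2[nH]ccc12`: > 100000 nM, a limit
Compound 3 `Cc1cc(N2CC[C@@H](C)[C@@H](N(C)c3ncnc4[nH]ccc34)C2)n2nc(SCC3CCCCC3)nc2n1`: 11500 nM

In a functional assay on HGC-27 cells (Homo sapiens) for inhibition, read by MTT assay, with a stated time of 72 h (a higher number here means a weaker inhibitor, a lower number a stronger inhibitor), compound 1 gives > 100000 nM, which is a limit and not a number. It is not alone there: the limit of > 100000 nM in this assay, at which 2 of the 3 values shown sit.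

Compound 4 `Cc1ccc(CSc2nc3nc(C)cc(N4CC[C@@H](C)[C@@H](N(C)c5ncnc6[nH]ccc56)C4)n3n2)cc1` keeps the core of compound 1 and changes one group: 4-methylphenyl in place of 1H-benzimidazol-2-yl on a saturated chain carbon bound to a sulfur. Among the measured compounds shown here, the only measured step at this place is an at least 8.6-fold lower number from compound 1 to compound 3 (0.93 log units; beyond the scatter). There too, 1H-benzimidazol-2-yl leaves and an all-carbon group enters on a saturated chain carbon bound to a sulfur. On that single step, a move in the same direction is expected in this assay, towards compound 3 at 11500 nM. Cyclohexyl and 4-methylphenyl are different groups, however, so the expectation is loose, and compound 4 could also return only a limit. The expected step is an at least 5.0-fold lower number from compound 1 to compound 4 (0.69 log units; beyond the scatter). For compound 4 the estimated value is 20000 nM, with an expected range of 6000 nM to 90000 nM.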

Compound 4, half-maximal inhibitory concentration: 15200 nM
The estimate for compound 4 lay 1.3-fold (0.12 log units) above the measured number; low and high end bracket the measured number.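

In this assay, an at least 6.5-fold lower number from compound 1 to compound 4 (0.81 log units; beyond the scatter) shows that the drop on losing 1H-benzimidazol-2-yl at this saturated chain carbon bound to a sulfur is not tied to cyclohexyl, since 4-methylphenyl, a second all-carbon group, gives it too. Between those two groups the data draw no distinction: a 1.3-fold higher number from compound 3 to compound 4 (0.12 log units; within the scatter), so an aromatic ring of carbon only and cyclohexyl cannot be told apart here. The full size of both drops from compound 1 stays unknown, as that compound's value is a limit and not a number: the limit of > 100000 nM in this assay, at which 2 of the 4 values shown sit.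

The compounds shown leave open whether the methyl of 4-methylphenyl plays any part, which plain phenyl or 4-chlorophenyl would test. They also leave open whether a pyridinyl group or an amine at this place would stay with compound 1 or join compound 3 and compound 4.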